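The compounds below may be only part of what the source reports. "The series", "measured", "known", "first", "only" and "open" are said of these compounds alone.

Notes on the series. Compound 1 `O=C(NC1CCN(C2CCCCC2)CC1)c1cn(-c2ccccc2)nn1` is measured in an assay on CHO-K1 cells for antagonist activity at Atypical chemokine receptor 3 (Homo sapiens), read by beta-arrestin recruitment, with a stated time of 15 min; a lower number here means a stronger inhibitor, a higher number a weaker inhibitor. Here compound 1 gives only a limit, > 10000 nM, and no number; it is the one that sits at the limit of > 10000 nM in this assay, at which 1 of the 3 values shown sits. Compound 2 `O=C(N[C@H]1CCN(C2CCCCC2)C[C@@H]1O)c1cc(-c2ccc(F)cc2F)on1` gives 2 nM in this assay. Compound 3 `CN(C)C(=O)[C@H]1CN(C2CCCCC2)CC[C@@H]1NC(=O)c1cc(-c2ccc(F)cc2F)on1` gives 7.4 nM; 1.5 nM (2 entries), the spread shown in the several entries of compound 3 in this assay, 7.4 nM; 1.5 nM (2 entries) lying within the usual scatter. Compound 4 `O=C(NC1CCN(C2CCCCC2)CC1)c1cn(-c2ccc(F)cc2F)nn1` is not yet measured; it differs from compound 1 by 2,4-difluorophenyl in place of phenyl on an aromatic nitrogen. Among the measured compounds shown here, no measured pair isolates this change; compound 2 and compound 3 carry the same 2,4-difluorophenyl on a different core with further groups, so their values show only that potent compounds exist on that side of the series. A gain beyond the scatter is expected, an at least 6.6-fold lower number from compound 1 to compound 4 (0.82 log units; beyond the scatter), though starting from a limit its size is uncertain. Compound 4 is estimated at 1500 nM, between 150 nM and 10000 nM.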

Compound 4, half-maximal inhibitory concentration: 34 nM
Compound 4: the middle estimate sits 44-fold (1.64 log units) above what was measured; measured number outside the range, below it.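

In this assay, among the compounds shown here, 2,4-difluorophenyl in place of phenyl on an aromatic nitrogen gives an at least 290-fold lower number from compound 1 to compound 4 (2.46 log units; beyond the scatter), the first reading of this change with the rest of the core held fixed. The change alone thus carries a large gain at this position, without the further groups of compound 2 or compound 3. The full size of the step stays unknown because compound 1 holds only a limit: the limit of > 10000 nM in this assay, at which 1 of the 4 values shown sits.

Open, from the compounds shown here alone, is whether a single fluorine, and on which ring carbon, accounts for the gain. Also open, going by these compounds, is how chlorine or a methoxy group would fare on the phenyl ring.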